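This account rests on a few compounds, and the source may have more. Where it says the series, first, only, none or still open, it means among the compounds named here.

Measured compounds in an ADME assay on Vero cells (Chlorocebus sabaeus) for cytotoxicity, read by sulforhodamine B assay, with a stated time of 72 h; a lower number here means a stronger inhibitor, a higher number a weaker inhibitor:
- compound 1 `CN1Cc2ccc(OCc3ccc([N+](=O)[O-])cc3)cc2[C@@H](O)C1`: compound 1 gives > 50000 nM, which is a limit of the assay and not a number.
- compound 2 `COc1cccc(-c2ccc(COc3ccc4c(c3)[C@@H](O)CN(C)C4)cc2)c1`: compound 2 gives 10800 nM.
- compound 3 `CN1Cc2ccc(OCc3ccc(-c4ccc(Cl)cc4)cc3)cc2[C@@H](O)C1`: compound 3 gives 21700 nM.

Compound 3 sits within the scatter of compound 2, as a 2.0-fold higher number from compound 2 to compound 3 (0.30 log units; within the scatter) shows; its distance from compound 1 is an at least 2.3-fold lower number from compound 1 to compound 3 (0.36 log units; beyond the scatter).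

Compound 4 `CN1Cc2ccc(OCc3ccc(-c4ccc(-c5ccccc5)cc4)cc3)cc2[C@@H](O)C1` follows from compound 3 by phenyl in place of chloro on an aromatic carbon. Going by the values given here, the steps that bear on it are an at least 4.6-fold lower number from compound 1 to compound 2 (0.66 log units; beyond the scatter), an at least 2.3-fold lower number from compound 1 to compound 3 (0.36 log units; beyond the scatter) and a 2.0-fold higher number from compound 2 to compound 3 (0.30 log units; within the scatter): swapping one distal group for another between compound 2 and compound 3 stayed within the scatter, so a further distal swap in this assay is expected to move little, a 1.4-fold lower number from compound 3 to compound 4 (0.16 log units; within the scatter). Compound 4 is estimated at 15000 nM, with a range of 6000 nM to 40000 nM.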

Compound 4, half-maximal inhibitory concentration: 280 nM
Estimate against measurement, compound 4: 54-fold (1.73 log units) above; measured number outside the range, below it.
By their numbers in this assay, from the lowest: compound 4; then compounds 2 and 3 (each within the scatter of the next). At a limit, above all of these: compound 1.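

In this assay this position proves sensitive: phenyl in place of chloro gives a 78-fold lower number from compound 3 to compound 4 (1.89 log units; beyond the scatter), whereas the earlier swap of end groups gave only a 2.0-fold higher number from compound 2 to compound 3 (0.30 log units; within the scatter). The entering group adds one six-membered aromatic ring of carbon only, with no hydrogen-bond donors or acceptors, and a large step follows. Nothing measured here accounts for the size of this step. From the compounds shown here alone, whether cyclohexyl or a longer alkyl chain in place of the phenyl gives a step of this size stays open. Going by these compounds, the effect of an amine or a carboxylic acid there is also open.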